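Replacing the side-chain amine of compound 3 with a carboxymethylamine

The compounds below may be only part of what the source reports. "The series", "measured", "known", "first", "only" and "open" are said of these compounds alone.

Compound 3 `CCN(C)CCCOc1ccc2cc(NC(=O)c3ccc(O)c(CC=C(C)C)c3)c(=O)oc2c1C` gives 2190 nM in a functional assay on MCF7 cells (Homo sapiens) for antiproliferative activity (on this read-out lower numbers stand for stronger inhibition and higher numbers for weaker inhibition), the highest of the three numbers here. Compound 1 `CC(=O)Oc1ccc(C(=O)Nc2cc3ccc(OCC4CCN(C)C4)c(C)c3oc2=O)cc1CC=C(C)C` gives 1880 nM, which lies within the scatter of compound 3, while compound 2 `CC(=O)Oc1ccc(C(=O)Nc2cc3ccc(OCCC4CCCCN4)c(C)c3oc2=O)cc1CC=C(C)C` gives 710 nM, a lower number beyond the scatter. Compound 4 `CC(C)=CCc1cc(C(=O)Nc2cc3ccc(OCCCNCC(=O)O)c(C)c3oc2=O)ccc1O` differs from compound 3 by (carboxymethyl)amino in place of ethyl(methyl)amino on a saturated chain carbon, three bonds along the chain from an oxygen on an aromatic ring. Within the data shown here, the only measured step, a 2.6-fold lower number from compound 1 to compound 2 (0.42 log units; beyond the scatter), also exchanges the amine on the side chain and is modest in size. Among the measured compounds shown here, no measured pair tests a carboxymethyl group, so the step from compound 3 to compound 4 is expected to stay small, leaning toward a higher number, written as a 1.4-fold higher number from compound 3 to compound 4 (0.14 log units; within the scatter). Compound 4 is therefore estimated at 3000 nM, within a range from 1000 nM to 9000 nM.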

Compound 4, half-maximal inhibitory concentration: 18100 nM
Compound 4: middle estimate off by 6.0-fold (0.78 log units), on the low side; measured number outside the range, above it.
By their numbers in this assay, from the lowest: compound 2; then compounds 1 and 3 (each within the scatter of the next); then compound 4.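

In this assay, this end of the side chain responds to what the amine carries: (carboxymethyl)amino in place of ethyl(methyl)amino gives an 8.3-fold higher number from compound 3 to compound 4 (0.92 log units; beyond the scatter). The earlier exchange of one amine for another, a 2.6-fold lower number from compound 1 to compound 2 (0.42 log units; beyond the scatter), went the other way, whereas here the entering group brings a carboxylic acid and the number rises. No measurement at hand explains this rise.

Still open, on these data alone, is whether the carboxylic acid itself or the loss of the ethyl and methyl groups accounts for the change. A methyl ester of the acid, or a longer chain carrying the acid, would help separate the two.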